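Swapping Trifluoromethyl for Methoxy in Whole-Animal Inhibition

The source may hold more compounds than are shown below. What is called first, only, known or untested is meant among the compounds shown, and "the series" means these compounds.

Measured compounds:
- compound 1, `O=C(O)c1cnc(-c2cccc(C(F)(F)F)c2)[nH]c1=O`: 33 mg/kg
- compound 2, `COc1cccc(-c2ncc(C(=O)O)c(=O)[nH]2)c1`: 10 mg/kg
- compound 3, `O=C(O)c1cnc(-c2ccc(C(F)(F)F)cc2)[nH]c1=O`: > 5 mg/kg (a limit, not a number)

All three were tested in a functional assay on the whole organism (strain Sprague-Dawley) for inhibition, with Rattus norvegicus as the target, with a stated time of 10 min; on this read-out higher numbers stand for an effect only at larger amounts of compound and lower numbers for an effect already at smaller amounts. Compound 1 and compound 2 share a core and differ by methoxy in place of trifluoromethyl on an aromatic carbon. That change gave a 3.3-fold lower number from compound 1 to compound 2 (0.52 log units; beyond the scatter).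

Compound 3 carries the same atoms as compound 1, joined differently; how its core differs from that of compound 1 is not broken down here. For compound 3 the assay reports only (the limit of > 5 mg/kg in this assay, at which 1 of the 3 values shown sits), so no number is known for it.

Compound 4, `COc1ccc(-c2ncc(C(=O)O)c(=O)[nH]2)cc1`, is not yet measured. It differs from compound 3 by methoxy in place of trifluoromethyl on an aromatic carbon. This is the same kind of change as that from compound 1 to compound 2, but not the same: in the measured pair the group sits meta to a large group, in the new pair para to a large group.

Since compound 3 gives only a limit, an expected value for compound 4 must rest loosely on the measured step: a step that the limit leaves unreadable from compound 3 to compound 4 is expected, by analogy with a 3.3-fold lower number from compound 1 to compound 2 (0.52 log units; beyond the scatter). Compound 4 is therefore estimated at 15 mg/kg, with a plausible range from 3 mg/kg to 60 mg/kg.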

Compound 4, dose for 50% inhibition: > 5 mg/kg
Compound 4 was reported as a limit (the forecaster's own chance of this, stated with the estimate: 40%); the middle value lies beyond the limit too.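

Compound 3 and compound 4 are both reported only as a limit, not as a number, so the step between them cannot be read: the limit of > 5 mg/kg in this assay, at which 2 of the 4 values shown sit.

On these data alone, it remains open whether methoxy in place of trifluoromethyl, para to a large group, changes the read-out at all, or moves it the same way as between compound 1 and compound 2.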